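A few compounds are considered here, and "the series" means these few. Any claim that something is new, unique, unknown or untested is made for them only; others in the source may bear on it.

Working notes on the series.

Compound 2 `CC(C)c1onc(-c2c(Cl)cccc2Cl)c1COc1ccc(CCCC(=O)O)cc1` carries the shared core of compound 1 `CC(C)c1onc(-c2c(Cl)cccc2Cl)c1COc1ccc(CNc2ccc(CC(=O)O)cc2)cc1` with a 2-carboxyethyl chain in place of the (4-(carboxymethyl)phenyl)amino group. Among the compounds with values here, in an assay on HEK-293T cells for activation of Bile acid receptor (Homo sapiens), read by a luciferase reporter, with a stated time of 14 h (a lower number here means that less compound is needed, a higher number that more compound is needed for the effect), compound 2 gives 6000 nM, the highest of the two numbers measured so far; compound 1 gives 1600 nM in this assay. Within the data shown here, the one step between measured compounds, a 3.8-fold higher number from compound 1 to compound 2 (0.57 log units; beyond the scatter), concerns the acid-bearing chain and not the aryl group on the isoxazole.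

Compound 3 `CC(C)c1onc(-c2ccccc2Cl)c1COc1ccc(CCCC(=O)O)cc1` differs from compound 2 by hydrogen in place of chloro on an aromatic carbon; cut one bond further out, the change reads 2,6-dichlorophenyl to 2-chlorophenyl. Among the measured compounds shown here, no measured step in this assay touches this part of the molecule, so the direction and size of the step cannot be read from the data in hand. With nothing to anchor it, the expectation for compound 3 is a number near that of compound 2, with a wide range that allows a modest move in either direction, and the step expected is a 1.5-fold higher number from compound 2 to compound 3 (0.18 log units; within the scatter). In this assay compound 3 is estimated at 9000 nM, with a range from 3000 nM to 30000 nM.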

Compound 3, half-maximal effective concentration: 3800 nM
Compound 3: the middle estimate sits 2.4-fold (0.37 log units) above what was measured, and the stated range covers the measured number.
By their numbers in this assay, from the lowest: compound 1; then compounds 3 and 2 (each within the scatter of the next).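

Hydrogen in place of chloro on an aromatic carbon, which turns 2,6-dichlorophenyl into 2-chlorophenyl, gives a 1.6-fold lower number from compound 2 to compound 3 (0.20 log units; within the scatter) in this assay, so this change on the aryl group of the isoxazole cannot be told apart from repeat measurement. Within the data shown here, this is the first reading at this position, and with the 2-carboxyethyl chain held constant, one of the two chloro groups can be exchanged for hydrogen without a step beyond the scatter. The earlier step, a 3.8-fold higher number from compound 1 to compound 2 (0.57 log units; beyond the scatter), concerns the acid-bearing chain and lies beyond the scatter, while the new step does not; no data in hand bear on the reason for either result.

Open, from the compounds shown here alone, is how this assay would read for a phenyl group carrying no chloro at all, or for a methyl, methoxy or trifluoromethyl group in place of the remaining chloro. Also open, going by these compounds, is whether the 2-chlorophenyl group gives a step of the same size when the (4-(carboxymethyl)phenyl)amino chain of compound 1 is present, as only the 2-carboxyethyl chain has been read with this change.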